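The compounds below may be only part of what the source reports. "The series", "measured", "known", "first", "only" and "open" are said of these compounds alone.

Compound 3 `CC(C)=CCC/C(C)=C/CC1Cc2c(OCCCNC(=O)c3cccs3)cc(=O)n(CCCO)c2CC1(C)C` has the highest of the three numbers in a functional assay on PANC-1 cells (Homo sapiens) for inhibition, read by MTT assay, with a stated time of 24 h, tested at 10 uM (a higher number here means more inhibition at the concentration tested (going by the name of the read-out), a lower number less inhibition), giving 11.5%. Going by the values given here, compound 1 `CC(C)=CCC1Cc2c(OCCCNC(=O)c3cccs3)cc(=O)n(CCCO)c2CC1(C)C` gives 5.6% in this assay, a value within the scatter of compound 3, while compound 2 `CC(C)=CCC/C(C)=C/CC1Cc2c(OCCCNS(=O)(=O)c3ccc(Br)cc3)cc(=O)n(CCCO)c2CC1(C)C` gives 0%, the only number beyond the scatter. The two measured steps read a number 5.9 percentage points higher from compound 1 to compound 3 (within the scatter) and a number 11.5 percentage points higher from compound 2 to compound 3 (beyond the scatter). Compound 4 `CC(C)=CCC/C(C)=C/CC1Cc2c(OC(=O)Nc3ccc(F)c(Cl)c3)cc(=O)n(CCCO)c2CC1(C)C` differs from compound 3 in that ((3-chloro-4-fluorophenyl)carbamoyl in place of 3-(((thiophen-2-yl)carbonyl)amino)propyl on an oxygen on an aromatic ring). Among the compounds with values here, only one measured step touches the group on that oxygen, namely a number 11.5 percentage points higher from compound 2 to compound 3 (beyond the scatter), and it was modest, so no step beyond the scatter is expected here. Compound 4 is therefore estimated at 8%, between 0% and 25%, which amounts to an expected step of a number 3.5 percentage points lower from compound 3 to compound 4 (within the scatter).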

Compound 4, a percentage reported as inhibition, at one concentration (the size of the read-out at that concentration, not a potency): 0%
Compound 4: the middle estimate sits 8 percentage points above what was measured, and the stated range covers the measured number.
By their numbers in this assay, from the lowest: compounds 2, 4, 1 and 3 (each within the scatter of the next, the first and the last beyond it).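

Exchanging the whole group on the oxygen on an aromatic ring, rather than only the acyl or sulfonyl end of the chain, gives a number 11.5 percentage points lower from compound 3 to compound 4 (beyond the scatter) in this assay. So (3-chloro-4-fluorophenyl)carbamoyl does not keep the small inhibition seen with compound 3, and compound 4 at 0% reads like compound 2 at 0%. No measurement shown here explains this step. The compounds shown leave open whether a free amine at the end of the propyl chain, or a longer chain on that oxygen, would read differently. With every number low at one concentration, they also give no potency for any of these groups.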